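The source may hold more compounds than are shown below. What is called first, only, known or untested is meant among the compounds shown, and "the series" means these compounds.

Compound 1 `O=C(CCCCCCNC(=O)c1cc(=O)c(O)co1)Nc1ccccc1` was tested in a functional assay on HCT-116 cells (Homo sapiens) for inhibition, read by colorimetric assay, with a stated time of 3 days (on this read-out lower numbers stand for stronger inhibition and higher numbers for weaker inhibition), and compound 1 gives > 100000 nM, which is a limit of the assay rather than a measured number. Compound 1 thus sits at the limit of > 100000 nM in this assay, at which 1 of the 2 values shown sits. Compound 2 `Cc1ccc(S(=O)(=O)Nc2ccc(NC(=O)CCCCCCNC(=O)C(O)(O)C(F)(F)F)cc2)cc1`, built around a different core, was run in this assay as well, and compound 2 gives 17200 nM. Compound 3 `C/C(=N\O)C(=O)NCCCCCCC(=O)Nc1ccccc1` has not yet been measured. It differs from compound 1 in one place: a group of 4 heavy atoms (2 carbon, 1 nitrogen, 1 oxygen; no ring) in place of a group of 8 heavy atoms (5 carbon, 3 oxygen; one six-membered aromatic ring with 1 hetero atom), on a carbonyl carbon. For the measured compounds named here, because compound 1 gives only (the limit of > 100000 nM in this assay, at which 1 of the 2 values shown sits), no measured step starts from it, and a change of this kind offers no footing for a large shift in either direction. Compound 3 is therefore expected to remain weak, with a step of an at least 1.2-fold lower number from compound 1 to compound 3 (0.09 log units; that floor lies within the scatter) that likely stays within the usual scatter. The estimate for compound 3 in this assay is 80000 nM, with a range from 20000 nM to 300000 nM.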

Compound 3, half-maximal inhibitory concentration: > 100000 nM
Compound 3: only a limit was reported (the forecaster's own chance of this, stated with the estimate: 60%); middle value at least 1.2-fold (0.09 log units) away from the limit.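

For the compounds shown here, compound 1 and compound 3 each give only a limit rather than a measured number in this assay, so no step between them can be read: the limit of > 100000 nM in this assay, at which 2 of the 3 values shown sit. On these data alone, whether the group of 4 heavy atoms differs at all from the group of 8 heavy atoms in inhibition stays open.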